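Methyl on the ring amine of a cathepsin S inhibitor

The source may report more compounds than this note shows. Statements on the series, on what has been measured and on what is new or still open speak of the compounds shown alone.

Compound 1 `N#C[C@@]1(NC(=O)[C@@H](CC(=O)N2CCOCC2)CC2CCCCC2)CCNC1` was tested in an assay on isolated protein for inhibition of cathepsin S (Homo sapiens) (a lower number here means a stronger inhibitor, a higher number a weaker inhibitor), and gave 141 nM. Among the three compounds measured so far, compound 1 shows the highest number. Compound 3 `N#C[C@H](COCc1ccccc1)NC(=O)[C@@H](CC(=O)N1CCOCC1)CC1CCCCC1` gives 37 nM, a gap beyond the scatter, and compound 2 `CC1CCC(C[C@H](CC(=O)N2CCOCC2)C(=O)N[C@]2(C#N)CCN(C3CCCCC3)C2)CC1` gives 14 nM, the furthest from compound 1 and also beyond the scatter. Compound 2 carries a cyclohexyl group on its ring amine as well as a methyl on its cyclohexylmethyl group, so its two values with compound 1 cannot be split between those changes.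

Compound 4 `CN1CC[C@@](C#N)(NC(=O)[C@@H](CC(=O)N2CCOCC2)CC2CCCCC2)C1` differs from compound 1 in one place: methyl in place of hydrogen on an amine nitrogen in a ring. Among the measured compounds shown here, no measured pair shows this change on its own. Given that compound 2 with a substituted ring amine gives 14 nM, a small shift toward a lower number is expected, but close to the scatter. The step from compound 1 to compound 4 is therefore estimated as a 2.0-fold lower number from compound 1 to compound 4 (0.30 log units; within the scatter). Compound 4 is expected to give 70 nM, within a range from 25 nM to 200 nM.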

Compound 4, half-maximal inhibitory concentration: 155 nM
Compound 4: the middle estimate sits 2.2-fold (0.35 log units) below what was measured, and the stated range covers the measured number.
By their numbers in this assay, from the lowest: compound 2; then compound 3; then compounds 1 and 4 (each within the scatter of the next).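

In this assay, among the compounds shown here, methyl in place of hydrogen on the amine nitrogen in the ring gives a 1.1-fold higher number from compound 1 to compound 4 (0.04 log units; within the scatter), the first reading of a change at this position on its own. The ring nitrogen can therefore carry a single methyl with no change in this read-out beyond the scatter, so this smallest substituent separates compound 1 from compound 4 by nothing the assay can resolve. Nothing shown explains this result.

The compounds shown leave open whether a larger group on this nitrogen, such as benzyl or acetyl, would shift the number. Cyclohexyl on this nitrogen also remains unresolved, as it appears only in compound 2, alongside the methyl on the cyclohexylmethyl group, and no single step isolates it.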